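Aryl change at the benzylamine end: compound 4

This account rests on a few compounds, and the source may have more. Where it says the series, first, only, none or still open, it means among the compounds named here.

Measured in a toxicity assay on MCF-10A cells (Homo sapiens) for inhibition, read by MTT assay, with a stated time of 72 h; on this read-out higher numbers stand for weaker inhibition of growth and lower numbers for stronger inhibition of growth:
- compound 1 `O=S(=O)(NCCCCNCc1ccc(Br)cc1)c1cc(C(F)(F)F)cc(C(F)(F)F)c1` gives 3200 nM
- compound 2 `O=S(=O)(NCCCNCc1cccc(Cl)c1)c1cc(C(F)(F)F)cc(C(F)(F)F)c1` gives 7000 nM
- compound 3 `O=S(=O)(NCCCNCc1ccc(C(F)(F)F)cc1)c1cc(C(F)(F)F)cc(C(F)(F)F)c1` gives 3300 nM

Compound 2 holds the highest number of the three; the nearest is compound 3, reached by a 2.1-fold lower number from compound 2 to compound 3 (0.33 log units; beyond the scatter), and the other is a 2.2-fold higher number from compound 1 to compound 2 (0.34 log units; beyond the scatter), which also alters the chain.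

Compound 4 `COc1ccc(CNCCCNS(=O)(=O)c2cc(C(F)(F)F)cc(C(F)(F)F)c2)cc1` differs from compound 2 at one place: 4-methoxyphenyl in place of 3-chlorophenyl on a saturated chain carbon bound to an amine nitrogen.

Among the measured compounds shown here, only the step to compound 3 bears on this change at the same place, and it was modest. Another aryl swap at that carbon is therefore expected to move the number little, at most a modest lowering. For compound 4 the estimate is 4500 nM (range 2000 nM to 10000 nM), an expected step of a 1.6-fold lower number from compound 2 to compound 4 (0.19 log units; within the scatter).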

Compound 4, concentration for 50% growth inhibition: 3100 nM
Beside the measured number, compound 4's estimate is 1.5-fold (0.16 log units) above it; low and high end bracket the measured number.
By their numbers in this assay, from the lowest: compounds 4, 1 and 3 (each within the scatter of the next); then compound 2.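

At this carbon, 4-methoxyphenyl gives a step beyond the scatter from 3-chlorophenyl (a 2.3-fold lower number from compound 2 to compound 4 (0.35 log units; beyond the scatter)), the same direction as 4-(trifluoromethyl)phenyl, and the two para-free names cannot be told apart here (a 1.1-fold lower number from compound 3 to compound 4 (0.03 log units; within the scatter)). Compound 1, which also alters the chain, is not separated from compound 4 either (a 1.0-fold lower number from compound 1 to compound 4 (0.01 log units; within the scatter)). No measurement available accounts for these steps.

Still open, from the compounds shown here alone, is whether the step from compound 2 follows the chlorine or where it sits, which 4-chlorophenyl and 3-methoxyphenyl at this carbon would address. Also open, going by these compounds, is how a pyridyl ring would read there.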